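The source may report more compounds than this note shows. Statements on the series, on what has been measured and on what is new or still open speak of the compounds shown alone.

Measured so far in a functional assay on SK-MEL-28 cells (Homo sapiens) for inhibition, read by sulforhodamine B assay, with a stated time of 48 h; a lower number here means a stronger inhibitor of growth, a higher number a weaker inhibitor of growth:
- compound 1 `NS(=O)(=O)c1ccc(Nc2nc(N/N=C/c3ccc(C(F)(F)F)cc3)nc(Nc3ccccc3)n2)cc1` gives 2440 nM
- compound 2 `Cc1nn(-c2ccccc2)cc1/C=N/Nc1nc(Nc2ccccc2)nc(Nc2ccc(S(N)(=O)=O)cc2)n1` gives 1800 nM

On the numbers shown compound 2 sits at the lower end, yet a 1.4-fold lower number from compound 1 to compound 2 (0.13 log units; within the scatter) is within the scatter, so compound 1 and compound 2 cannot be told apart. Compound 3 `NS(=O)(=O)c1ccc(Nc2nc(N/N=C/c3ccccn3)nc(Nc3ccccc3)n2)cc1` differs from compound 2 by pyridin-2-yl in place of 3-methyl-1-phenyl-1H-pyrazol-4-yl on a carbon with a double bond to nitrogen. Within the data shown here, the only measured step at this position, a 1.4-fold lower number from compound 1 to compound 2 (0.13 log units; within the scatter), exchanged one aryl group for another on the same carbon and stayed within the scatter. No step beyond the scatter is therefore expected for compound 3 in this assay, estimated at 2200 nM within 900 nM to 5500 nM. The expected shift is a 1.2-fold higher number from compound 2 to compound 3 (0.09 log units; within the scatter).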

Compound 3, concentration for 50% growth inhibition: 750 nM
For compound 3 the middle estimate is 2.9-fold (0.47 log units) above the measured one; measured number below the stated range.
By their numbers in this assay, from the lowest: compound 3; then compounds 2 and 1 (each within the scatter of the next).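

In this assay, the group on the carbon with a double bond to nitrogen can move the number beyond the scatter: pyridin-2-yl gives a 2.4-fold lower number from compound 2 to compound 3 (0.38 log units; beyond the scatter) and also a 3.3-fold lower number from compound 1 to compound 3 (0.51 log units; beyond the scatter) in this series. The same change holds against both a two-ring group and 4-(trifluoromethyl)phenyl, so it does not depend on which of these it replaces. Nothing available explains this difference. From the compounds shown here alone, whether the ring nitrogen of pyridin-2-yl matters remains open, and plain phenyl or pyridin-4-yl on this carbon would address that. Going by these compounds, how a non-aromatic group, such as a cyclohexyl ring, would behave here is also open.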